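Three Limits and a Fourth Compound Awaiting Its Reading

The compounds below may be only part of what the source reports. "The series", "measured", "known", "first", "only" and "open" are said of these compounds alone.

Measured compounds:
compound 1, `CCCn1c(NC(=O)c2cc(C)nn2CC)nc2cc(C(=O)OC)cc(OC)c21`, gives > 100000 nM in an assay for activation of interferon regulatory factor 3 (Homo sapiens), read by a luciferase reporter, with a stated time of 20 h; a lower number here means that less compound is needed, a higher number that more compound is needed for the effect; this is a limit of the assay, not a number.
compound 2, `CCCn1c(NC(=O)c2nccc3ccccc23)nc2cc(C(N)=O)cc(OC)c21`, gives > 100000 nM in this assay; again a limit.
compound 3, `COc1cc(C(N)=O)cc2nc(NC(=O)c3nccc4ccccc34)n(CCCNC(=O)OCc3ccccc3)c12`, gives > 100000 nM in this assay; again a limit.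

Compound 3 therefore stands exactly where the two others stand, at the limit of > 100000 nM in this assay, at which 3 of the 3 values shown sit. Going by the values given here, the only step between measured compounds that differ in one place, a step that the two limits leave unreadable from compound 2 to compound 3, cannot be read because the limit of > 100000 nM in this assay, at which 3 of the 3 values shown sit, sits at both of its ends.

Compound 4, `COc1cc(C(N)=O)cc2nc(NC(=O)C3CCN(C)CC3)n(CCCNC(=O)OCc3ccccc3)c12`, differs from compound 3 by 1-methylpiperidin-4-yl in place of isoquinolin-1-yl on a carbonyl carbon. No measured step touches this change, so the three compounds give no reason to expect a step beyond the scatter in this assay in either direction. Compound 4 is therefore expected to give about 100000 nM, between 30000 nM and 300000 nM, most probably reported once more as a limit. That expectation amounts to a step of a number no higher from compound 3 to compound 4 (the limit leaves the size open).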

Compound 4, half-maximal effective concentration: > 100000 nM
Compound 4: no number, only a limit; the forecaster's own chance of this, stated with the estimate: 80%; the middle value sits exactly at the limit.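

No step can be read from compound 3 to compound 4, since both results are limits of the assay and not numbers: the limit of > 100000 nM in this assay, at which 4 of the 4 values shown sit. The compounds shown leave open how much of any of them is needed for the effect, and whether isoquinolin-1-yl or 1-methylpiperidin-4-yl on the carbonyl carbon changes that amount.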